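Taking the chloro off compound 3

A few compounds are considered here, and "the series" means these few. Any claim that something is new, unique, unknown or untested is made for them only; others in the source may bear on it.

In a functional assay on HeLa cells (Homo sapiens) for antiproliferative activity, read by MTT assay, with a stated time of 72 h (on this read-out lower numbers stand for stronger inhibition and higher numbers for weaker inhibition), three compounds with one shared core and different groups on the ring amide nitrogen have been measured. Compound 1 `COc1cccc(N2C(=O)COc3ccc(-c4cnc5ccccc5c4)cc32)c1`, with 3-methoxyphenyl, gives 11400 nM. Compound 2 `O=C1COc2ccc(-c3cnc4ccccc4c3)cc2N1C1CCCCC1`, with cyclohexyl, gives 19700 nM, and the change between them is a 1.7-fold higher number from compound 1 to compound 2 (0.24 log units; within the scatter).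

Compound 3 `O=C1COc2ccc(-c3cnc4ccccc4c3)cc2N1c1ccc(Cl)cc1`, with 4-chlorophenyl, is recorded only as a limit, > 40000 nM. Its place on the numbers is the limit of > 40000 nM in this assay, at which 1 of the 3 values shown sits, so it has no number of its own.

Compound 4 `O=C1COc2ccc(-c3cnc4ccccc4c3)cc2N1c1ccccc1` differs from compound 3 by hydrogen in place of chloro on an aromatic carbon, which is hydrogen in place of chloro on an aromatic carbon, turning 4-chlorophenyl into phenyl.

Among the measured compounds shown here, no measured step removes the chloro alone. Compound 1 offers the firmest guide, with an at least 3.5-fold higher number from compound 1 to compound 3 (0.54 log units; beyond the scatter), and compound 2 gives an at least 2.0-fold higher number from compound 2 to compound 3 (0.30 log units; that floor lies within the scatter), but both steps swap the whole group on the nitrogen. From the size of an at least 3.5-fold higher number from compound 1 to compound 3 (0.54 log units; beyond the scatter), a modest move to a lower number, meaning stronger inhibition, is expected, and compound 4 should come to lie near compound 1 and compound 2. The expected change is an at least 2.0-fold lower number from compound 3 to compound 4 (0.30 log units; that floor lies within the scatter). For compound 4 the estimated value in this assay is 20000 nM, with an expected range of 8000 nM to 40000 nM.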

Compound 4, half-maximal inhibitory concentration: > 40000 nM
Compound 4: no number, only a limit; the forecaster's own chance of this, stated with the estimate: 25%; middle value at least 2.0-fold (0.30 log units) from the limit.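

In this assay, taking the chloro off the 4-chlorophenyl group did not bring a readable number, so the chloro alone does not account for compound 3 having only a limit, and the step between compound 3 and compound 4 cannot be read, both compounds being recorded at the same limit: the limit of > 40000 nM in this assay, at which 2 of the 4 values shown sit.

Among the compounds shown here, the new compound also isolates the methoxy of compound 1 as a single change on the aromatic ring, for hydrogen in place of methoxy gives an at least 3.5-fold higher number from compound 1 to compound 4 (0.54 log units; beyond the scatter), a step beyond the scatter that the earlier comparisons, each swapping the whole group on the nitrogen, could not separate. Phenyl in place of cyclohexyl gives an at least 2.0-fold higher number from compound 2 to compound 4 (0.30 log units; that floor lies within the scatter), and since that floor lies within the scatter, it sets no firm order between these two groups.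

The compounds shown leave open whether a group other than methoxy on that phenyl ring, such as an amine or a carboxylic acid, would also give a readable number. They also leave open whether methoxy in the place the chloro holds in compound 3 would do the same as it does in compound 1.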